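Chloro Added to the Fluorophenyl: Rat Exposure Outlook

This account rests on a few compounds, and the source may have more. Where it says the series, first, only, none or still open, it means among the compounds named here.

Measured compounds:
compound 1 `CC(C)S(=O)(=O)N1CCN(c2cnn(-c3cccc(F)c3)c(=O)c2OC2CCCC2)CC1`: 670 ng.h/mL
compound 2 `CC(C)S(=O)(=O)N1CCN(c2cnn(-c3cccc(F)c3)c(=O)c2OC2CCC(F)(F)C2)CC1`: 470 ng.h/mL

In an ADME assay on the whole organism for pharmacokinetics, with Rattus norvegicus as the target, with a stated time of 6 h, at a dose of 10 mg/kg by the oral route (on this read-out lower numbers stand for lower exposure and higher numbers for higher exposure at the dose given), compound 1 gives 670 ng.h/mL. Within the data shown here, compound 2 gives 470 ng.h/mL, and the step of a 1.4-fold lower number from compound 1 to compound 2 (0.15 log units; within the scatter) lies within the scatter, so compound 1 stands level with the only other measured compound. Compound 3 `CC(C)S(=O)(=O)N1CCN(c2cnn(-c3cc(F)cc(Cl)c3)c(=O)c2OC2CCCC2)CC1` differs from compound 1 by chloro in place of hydrogen on an aromatic carbon. Among the measured compounds shown here, no measured step touches this ring; the single step, a 1.4-fold lower number from compound 1 to compound 2 (0.15 log units; within the scatter), concerns the cyclopentyl on the oxygen and gives no direct guide. For compound 3 the expected step is therefore a 1.2-fold lower number from compound 1 to compound 3 (0.09 log units; within the scatter), essentially none beyond the scatter. Compound 3 is estimated at 550 ng.h/mL, within 220 ng.h/mL to 1400 ng.h/mL.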

Compound 3, area under the concentration-time curve: 490 ng.h/mL
Beside the measured number, compound 3's estimate is 1.1-fold (0.05 log units) above it; measured number inside the range.
By their numbers in this assay, from the lowest: compounds 2, 3 and 1 (each within the scatter of the next).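

In this assay, among these compounds, going from 3-fluorophenyl to 3-chloro-5-fluorophenyl gives a 1.4-fold lower number from compound 1 to compound 3 (0.14 log units; within the scatter), the first reading on this ring, and it does not separate the two compounds. The aromatic carbon meta to a fluoro group therefore carries a chloro with no difference in exposure that can be told from the scatter. No supporting data bear on the reason for this result. As far as these compounds go, it remains open whether a nitrile or a methoxy group on this carbon would give a step beyond the scatter. Also open, from the compounds shown here alone, is how the chloro would read alongside the 3,3-difluorocyclopentyl.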